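The source may report more compounds than this note shows. Statements on the series, on what has been measured and on what is new or still open speak of the compounds shown alone.

Measured so far:
- Compound 1, `Cc1ccc2cc(C(C)N(Cc3ccc(F)cc3)Cc3ccc(C(C)C)cc3)c(=O)[nH]c2c1`: > 33000 nM
- Compound 2, `Cc1ccc2[nH]c(=O)c(CN(Cc3ccc(OCC(=O)O)cc3)Cc3ccc(C(C)(C)C)cc3)cc2c1`: > 10000 nM
- Compound 3, `CC(C)c1ccc2[nH]c(=O)c(CN(Cc3ccc(C(C)(C)C)cc3)C(C)c3ccc(F)cc3)cc2c1`: 13100 nM

Of the compounds shown here, three share a core and have been tested in a toxicity assay on MDCK cells (Canis lupus familiaris) for cytotoxicity, read by crystal violet staining, with a stated time of 48 h; a higher number here means that more compound is tolerated, a lower number that less compound is tolerated. Compound 2, built on that core with a 4-(carboxymethoxy)phenyl group, gives only a limit in this assay, > 10000 nM, so no number is known for it. Compound 1 likewise gives only a limit, > 33000 nM. Among the measured compounds shown here, compound 3 is the one compound with a number, 13100 nM. Two of the three values are therefore limits, one at the limit of > 10000 nM in this assay, at which 1 of the 3 values shown sits, and one at the limit of > 33000 nM in this assay, at which 1 of the 3 values shown sits, and all three sit in the same broad region of this assay.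

Compound 4, `Cc1ccc2[nH]c(=O)c(CN(Cc3ccc(C(C)(C)C)cc3)Cc3ccc(N(C)C)c(Cl)c3)cc2c1`, has not yet been measured. It differs from compound 2 in one place: 3-chloro-4-(dimethylamino)phenyl in place of 4-(carboxymethoxy)phenyl on a saturated chain carbon bound to an amine nitrogen. For the measured compounds named here, no two measured compounds differ in a single place, so no measured step shows what such a change does in this assay; a step of modest size in either direction, or none beyond the scatter, is possible.

For compound 4 a value of 12000 nM is expected, between 4000 nM and 33000 nM, close to what compound 3 shows with 13100 nM. That estimate means a step that the limit leaves unreadable from compound 2 to compound 4, which is expected to stay small.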

Compound 4, half-maximal cytotoxic concentration: > 10000 nM
Compound 4: a limit, no number; the forecaster's own chance of this, stated with the estimate: 30%; the middle value does not contradict the limit.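

Compound 2 and compound 4 each give only a limit in this assay, not a number, so the step between them cannot be read. The compounds shown leave open whether 3-chloro-4-(dimethylamino)phenyl in place of 4-(carboxymethoxy)phenyl changes how much compound the cells tolerate.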